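Bromine to fluorine on the aryl piperazine of compound 3

The compounds below may be only part of what the source reports. "The series", "measured", "known", "first", "only" and "open" are said of these compounds alone.

Compound 1 `CCCn1c(=O)[nH]c2nc(-c3ccc(S(=O)(=O)N4CCN(c5cccc(Br)c5)CC4)cc3)[nH]c2c1=O`: 27%
Compound 2 `CCCn1c(=O)[nH]c2nc(-c3ccc(S(=O)(=O)N4CCN(Cc5ccc(Br)cc5)CC4)cc3)[nH]c2c1=O`: 28%
Compound 3 `CCCn1c(=O)[nH]c2nc(-c3ccc(S(=O)(=O)N4CCN(c5ccccc5Br)CC4)cc3)[nH]c2c1=O`: 20%

In an assay on CHO cells for displacement of a labelled ligand from adenosine receptor A3 (Homo sapiens), read by scintillation counting, with a stated time of 45 min, tested at 1 uM, in the presence of a further agent that is not named here (on this read-out lower numbers stand for less inhibition and higher numbers for more inhibition at the one concentration tested (going by the name of the read-out)), the three measured compounds sit close together. Compound 3 gives the lowest number of the three, yet its gap to compound 1, a number 7 percentage points lower from compound 1 to compound 3 (within the scatter), and to compound 2, a number 8 percentage points lower from compound 2 to compound 3 (within the scatter), both lie within the scatter, as does a number 1 percentage points higher from compound 1 to compound 2 (within the scatter). Nothing among these values therefore separates one compound from another.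

Compound 4 `CCCn1c(=O)[nH]c2nc(-c3ccc(S(=O)(=O)N4CCN(c5cccc(F)c5)CC4)cc3)[nH]c2c1=O` is not yet measured. Its change from compound 3 is 3-fluorophenyl in place of 2-bromophenyl on an amine nitrogen in a ring.

Among the measured compounds shown here, two measured steps touch the same group on the same ring nitrogen: the step from compound 1 to compound 3 swaps one bromophenyl for another, and the step from compound 2 to compound 3 swaps a bromobenzyl for a bromophenyl; both stayed within the scatter. For the measured compounds named here, no measured compound carries a fluorophenyl, so the effect of fluorine is unknown here. Compound 4 is therefore expected to show no step beyond the scatter, a number 4 percentage points higher from compound 3 to compound 4 (within the scatter), and is estimated at 24% with a range from 10% to 38%.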

Compound 4, a percentage reported as inhibition, at one concentration (the size of the read-out at that concentration, not a potency): 44%
The estimate for compound 4 lay 20 percentage points below the measured number; the measured number lies above the stated range.
By their numbers in this assay, from the lowest: compounds 3, 1 and 2 (each within the scatter of the next); then compound 4.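

In this assay, among the compounds shown here, the ring amine nitrogen now proves sensitive to what its aryl group carries: fluoro in place of bromo on an aromatic carbon, the only change between the two compounds, gives a number 17 percentage points higher from compound 1 to compound 4 (beyond the scatter). For the compounds shown here, the other two steps to the new compound point the same way, a number 24 percentage points higher from compound 3 to compound 4 (beyond the scatter) and a number 16 percentage points higher from compound 2 to compound 4 (beyond the scatter), whereas the swaps among the three bromine compounds all stayed within the scatter, which places the halogen, rather than the differences among those bromine-bearing groups, at the centre of the only clear change in this set. Nothing shown here accounts for this rise.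

Going by these compounds, whether the rise belongs to fluorine generally or to the 3-fluorophenyl group alone stays open, as does the outcome for a 2-fluorophenyl or 4-fluorobenzyl group. How chloro, methoxy or nitrile would compare at the same place is also unknown.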